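The source may report more compounds than this note shows. Statements on the series, on what has been measured and on what is new or still open speak of the compounds shown alone.

In a functional assay on HeLa cells (Homo sapiens) for inhibition, read by sulforhodamine B assay (a lower number here means a stronger inhibitor of growth, a higher number a weaker inhibitor of growth), compound 2 `CC1=CC(=O)[C@H]2C(C)(C)CCC[C@]2(C)[C@H]1/C=C/c1ccoc1` gives 63200 nM and compound 1 `CC1(C)CCC[C@]2(C)[C@@H](/C=C/C3=CCOC3=O)C(C=O)=CC(=O)[C@@H]12` gives 76900 nM, two numbers within the usual scatter of each other. Compound 3 `CC1=CC(=O)[C@H]2C(C)(C)CCC[C@]2(C)[C@H]1/C=C/C1=CCOC1=O` is still unmeasured and differs from compound 2 by one swap: a group of 6 heavy atoms (4 carbon, 2 oxygen; one five-membered non-aromatic ring with 1 hetero atom) in place of a group of 5 heavy atoms (4 carbon, 1 oxygen; one five-membered aromatic ring with 1 hetero atom), on a double-bonded chain carbon bound to a double-bonded chain carbon. The entering five-membered non-aromatic ring also occurs in compound 1, which gives 76900 nM but differs elsewhere, so no step beyond the scatter is expected in either direction. The estimated change is a 1.1-fold lower number from compound 2 to compound 3 (0.02 log units; within the scatter). The expected value for compound 3 is 60000 nM, with an estimated range of 22000 nM to 120000 nM.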

Compound 3, concentration for 50% growth inhibition: 83600 nM
Compound 3: the middle estimate sits 1.4-fold (0.14 log units) below what was measured; the range from low to high includes it.
By their numbers in this assay, from the lowest: compounds 2, 1 and 3 (each within the scatter of the next).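

In this assay, the non-aromatic five-membered ring with its two oxygens in place of furan-3-yl, on a double-bonded chain carbon bound to a double-bonded chain carbon, gives a 1.3-fold higher number from compound 2 to compound 3 (0.12 log units; within the scatter). Methyl in place of formyl on a double-bonded ring carbon gives a 1.1-fold higher number from compound 1 to compound 3 (0.04 log units; within the scatter), so neither single change separates these compounds in this read-out. No separate evidence bears on this result. As far as these compounds go, whether an amine or a carboxylic acid on that chain carbon would give a step beyond the scatter remains open. So does whether the swap from formyl to methyl would read the same with furan-3-yl in place.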